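Drawing in a stereocentre: from compound 2 to compound 4

The compounds below may be only part of what the source reports. "The series", "measured", "known", "first", "only" and "open" are said of these compounds alone.

Of the compounds shown here, three sharing one core have been measured in a functional assay on MCF7 cells (Homo sapiens) for cytotoxicity, read by MTT assay, with a stated time of 72 h; on this read-out higher numbers stand for weaker inhibition and lower numbers for stronger inhibition. Compound 1 `CN1CCN(CCCCCCn2c3c(c4ccccc42)C(=O)c2c[n+]([O-])c4ccccc4c2C3=O)CC1` gives 400 nM. Among the compounds with values here, compound 3 `O=C1c2c[n+]([O-])c3ccccc3c2C(=O)c2c1c1ccccc1n2CCN1CCCC1` gives 320 nM, and the change a 1.3-fold lower number from compound 1 to compound 3 (0.10 log units; within the scatter) is the only single-point step among them. Compound 2 `CC1(C)OCC(Cn2cc(Cn3c4c(c5ccccc53)C(=O)c3c[n+]([O-])c5ccccc5c3C4=O)nn2)O1` gives 290 nM; its number is the lowest of the three, but its gaps to compound 3 and to compound 1 both lie within the scatter, so the three are best read as alike in this assay.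

Compound 4 `CC1(C)OC[C@H](Cn2cc(Cn3c4c(c5ccccc53)C(=O)c3c[n+]([O-])c5ccccc5c3C4=O)nn2)O1` is the next step. The difference the two compounds have the same atoms and bonds; at least one stereo element is drawn with a configuration in one of them and without one in the other: 1 of 1 stereo elements differ; a stereocentre at a saturated ring carbon is drawn without a configuration in compound 2 and S in compound 4 leaves the atoms and bonds untouched; only a stereocentre at a saturated ring carbon, drawn without a configuration in compound 2, is drawn as S in compound 4. Within the data shown here, no measured step bears on a stereocentre, and the one measured step, that from compound 1 to compound 3, was itself within the scatter. On that basis no step beyond the scatter is expected from compound 2 to compound 4, so the expected change is no change at the digits printed from compound 2 to compound 4 (within the scatter). For compound 4 the estimated value in this assay is 290 nM, with a range from 150 nM to 600 nM.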

Compound 4, half-maximal inhibitory concentration: 530 nM
Estimate against measurement, compound 4: 1.8-fold (0.26 log units) below, and the stated range covers the measured number.
By their numbers in this assay, from the lowest: compounds 2, 3, 1 and 4 (each within the scatter of the next).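

In this assay, the pair that isolates a stereocentre gives a 1.8-fold higher number from compound 2 to compound 4 (0.26 log units; within the scatter). Within the data shown here, no other measured step touches stereochemistry, and this one shows that a stereocentre at this saturated ring carbon, drawn as S, leaves the cytotoxicity read-out within the usual spread of repeat measurements, with the atoms and bonds unchanged. Even so, the pair cannot be read as one mirror-image form against the other, because a configuration is stated on only one side: the fact that one of compounds 2 and 4 is drawn with a defined configuration and the other without, at the place where they differ

From the compounds shown here alone, what compound 2 contains at this carbon stays unknown from its drawing, so the R form remains the direct test of whether configuration here matters at all in this assay. Going by these compounds, it is also open whether the same indifference to configuration would hold if the ring carrying this stereocentre gave way to an open-chain diol or to a primary amine on the same triazole-linked side chain.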